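The source may report more compounds than this note shows. Statements on the series, on what has been measured and on what is new or still open speak of the compounds shown alone.

Measured so far in an ADME assay on C8166 cells (Homo sapiens) for cytotoxicity, read by MTT assay; a higher number here means that more compound is tolerated, a lower number that less compound is tolerated:
- compound 1, `Cc1ccc(C(O)c2cc(Cl)ccc2OCC(=O)Nc2ccc(S(N)(=O)=O)cc2C)cc1`: 38700 nM
- compound 2, `Cc1cc(S(N)(=O)=O)ccc1NC(=O)COc1ccc(Cl)cc1C(O)c1cccc(F)c1`: 37600 nM

Compound 2 has the lowest of these two numbers, and its nearest neighbour is compound 1, a gap within the scatter. Compound 3, `Cc1cc(S(N)(=O)=O)ccc1NC(=O)COc1ccc(Cl)cc1C(O)c1cccc2ccccc12`, is not yet measured; it differs from compound 2 by naphthalen-1-yl in place of 3-fluorophenyl on a saturated chain carbon bound to an aromatic carbon and an oxygen on a saturated carbon. For the measured compounds named here, the one step that bears on this place, a 1.0-fold lower number from compound 1 to compound 2 (0.01 log units; within the scatter), swapped one aromatic group for another without moving the number. The shared core is unchanged, so for compound 3 a step of about a 1.3-fold lower number from compound 2 to compound 3 (0.10 log units; within the scatter) is expected, within the scatter. Compound 3 is estimated at 30000 nM, between 12000 nM and 75000 nM.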

Compound 3, half-maximal cytotoxic concentration: 31100 nM
Beside the measured number, compound 3's estimate is 1.0-fold (0.02 log units) below it; the measured number falls inside the stated range.
By their numbers in this assay, from the lowest: compounds 3, 2 and 1 (each within the scatter of the next).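

In this assay, replacing 3-fluorophenyl with naphthalen-1-yl takes the group on this carbon from one aromatic ring to 2, yet the result is a 1.2-fold lower number from compound 2 to compound 3 (0.08 log units; within the scatter). Against the 4-methylphenyl of compound 1, the same group gives a 1.2-fold lower number from compound 1 to compound 3 (0.09 log units; within the scatter). This position has therefore now held a larger, two-ring group as well as single-ring groups, with no step beyond the scatter.

Going by these compounds, whether an amine or a carboxylic acid at this position would move the number remains open. No measurement at hand explains why these three numbers stay so close.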